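A few compounds are considered here, and "the series" means these few. Any claim that something is new, unique, unknown or untested is made for them only; others in the source may bear on it.

Compound 2, `Cn1c(=O)n(C2OC(CO)[C@@H](O)[C@H]2O)c2nc(N)nc(O)c21`, gives the lowest of the two numbers shown so far in a functional assay on YAC-1 cells (Mus musculus) for activation (on this read-out higher numbers stand for an effect only at larger amounts of compound and lower numbers for an effect already at smaller amounts), with 56 uM. Among the measured compounds shown here, compound 1, `Nc1nc(O)c2c(n1)n(C1OC(CO)[C@@H](O)[C@H]1O)c(=O)n2Cc1ccc(Cl)c(Cl)c1`, carries a 3,4-dichlorophenyl group on the same chain carbon and in this assay compound 1 gives 110 uM; the step of a 2.0-fold lower number from compound 1 to compound 2 (0.29 log units; within the scatter) is the only measured step. Compound 3, `NC(=O)Cn1c(=O)n(C2OC(CO)[C@@H](O)[C@H]2O)c2nc(N)nc(O)c21`, differs from compound 2 by carbamoyl in place of hydrogen on a saturated chain carbon bound to an aromatic nitrogen. For the measured compounds named here, the one measured step bears only loosely on this change: taking away a large aromatic group gave a small shift within the scatter, which suggests that this chain carbon tolerates alteration without a large swing in the read-out. Adding a small group there is therefore expected to bring a step of a 1.1-fold higher number from compound 2 to compound 3 (0.03 log units; within the scatter), that is, no movement beyond the scatter. Compound 3 is thus estimated at 60 uM, with a range from 20 uM to 180 uM.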

Compound 3, concentration for half-maximal effect: 90 uM
Compound 3: the middle estimate sits 1.5-fold (0.18 log units) below what was measured, within the range that was stated.
By their numbers in this assay, from the lowest: compounds 2, 3 and 1 (each within the scatter of the next).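

At this saturated chain carbon bound to an aromatic nitrogen, carbamoyl now joins hydrogen and 3,4-dichlorophenyl, and in this assay putting it in place of hydrogen gives a 1.6-fold higher number from compound 2 to compound 3 (0.21 log units; within the scatter). Putting it in place of the large aromatic group gives a 1.2-fold lower number from compound 1 to compound 3 (0.09 log units; within the scatter), so all three steps at this carbon now lie within the scatter, and groups as different as these cannot be told apart on this read-out. No measurement shown here offers an explanation for this result. Still open, as far as these compounds go, is whether an amine, a carboxylic acid or a longer chain on this carbon would move the number beyond the scatter. Also open is whether a change elsewhere on the shared core would do so, as every step shown stays at this one place.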